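Swapping acetyl for nitro on a piperazine aryl ring

A few compounds are considered here, and "the series" means these few. Any claim that something is new, unique, unknown or untested is made for them only; others in the source may bear on it.

For the measured compounds named here, compound 2 `CC(=O)c1ccc(N2CCN(CCCOc3ccc4c(c3)CCC4)CC2)cc1` gives 13% in a functional assay on the whole organism for inhibition, with Mus musculus as the target, at a dose of 25 mg/kg by the oral route (on this read-out lower numbers stand for less inhibition and higher numbers for more inhibition at the one dose given (going by the name of the read-out)), the lowest of the two numbers known, while compound 1 `COc1ccc(N2CCN(CCCOc3ccc4c(c3)CCC4)CC2)cc1` gives 60%. Compound 3 `O=[N+]([O-])c1ccc(N2CCN(CCCOc3ccc4c(c3)CCC4)CC2)cc1` differs from compound 2 in one place: nitro in place of acetyl on an aromatic carbon. Going by the values given here, only one measured step bears on this position, a number 47 percentage points lower from compound 1 to compound 2 (beyond the scatter), and it shows that a single change here can move the read-out strongly. Among the compounds with values here, no step compares nitro with acetyl directly, so the direction is open. Compound 3 is therefore expected to give 25%, within 0% to 55%, an estimated step of a number 12 percentage points higher from compound 2 to compound 3 (beyond the scatter).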

Compound 3, a percentage reported as inhibition, in the whole organism at one dose (the size of the read-out at that dose, not a potency): 0%
Beside the measured number, compound 3's estimate is 25 percentage points above it; the measured number falls inside the stated range.
By their numbers in this assay, from the lowest: compound 3; then compound 2; then compound 1.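

With the number of heavy atoms in the group unchanged, the read-out still shifts: this assay shows a number 13 percentage points lower from compound 2 to compound 3 (beyond the scatter) on going from acetyl to nitro. For the compounds shown here, replacing methoxy with nitro gives a number 60 percentage points lower from compound 1 to compound 3 (beyond the scatter), the largest step at this position so far, and the three groups now fall in the order methoxy, acetyl, nitro. No measurement here explains that order.

On these data alone, whether an amine or a carboxylic acid at this place would bring the number back towards that of compound 1 remains open. So does whether a longer chain in place of methoxy would keep it.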